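Aryl change on the cyclopropane amide: estimate for compound 4

The source may report more compounds than this note shows. Statements on the series, on what has been measured and on what is new or still open speak of the compounds shown alone.

Measured in a functional assay for agonist activity at G protein-coupled receptor 88 (Homo sapiens), read by HTRF and cAMP accumulation; a higher number here means that more compound is needed for the effect, a lower number that less compound is needed:
compound 1 `CN[C@@H](CC(C)C)CN(C(=O)[C@@H]1C[C@H]1c1ccccc1)c1ccc(-c2ccccc2)cc1`: 2 nM
compound 2 `CCC(CC)C(N)CCN(C(=O)[C@@H]1C[C@H]1c1ccccc1)c1ccc(-c2ccccc2)cc1`: 2 nM
compound 3 `CC[C@H](C)[C@H](N)CN(C(=O)[C@@H]1C[C@H]1c1ccc(Cl)cc1)c1ccc(-c2ccccc2)cc1`: 4300 nM

Compound 3 stands highest of the three numbers; its gaps to compound 1 and to compound 2 are both well beyond the scatter. Going by the values given here, compound 1 and compound 2 sit within the scatter of each other, no change at the digits printed from compound 1 to compound 2 (within the scatter), the only one-place step measured so far, and it concerns the amine-bearing chain, not the aryl ring on the cyclopropane.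

Compound 4 `CC[C@H](C)[C@H](N)CN(C(=O)[C@@H]1C[C@H]1c1ccc(F)cc1F)c1ccc(-c2ccccc2)cc1` differs from compound 3 in one place: 2,4-difluorophenyl in place of 4-chlorophenyl on a saturated ring carbon. Among the compounds with values here, no measured step bears on this change. Compound 1 and compound 2 carry an unsubstituted phenyl on the cyclopropane, but they also differ from compound 3 in the chain, so the two changes cannot be separated, and the weak number of compound 3 cannot be assigned to the 4-chlorophenyl alone.

Within the data shown here, with no step to lean on, compound 4 is expected to stay near compound 3 in this assay, the estimate being 3000 nM with a wide range from 400 nM to 15000 nM, that is a 1.4-fold lower number from compound 3 to compound 4 (0.16 log units; within the scatter).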

Compound 4, half-maximal effective concentration: 1300 nM
Estimate against measurement, compound 4: 2.3-fold (0.36 log units) above; low and high end bracket the measured number.
By their numbers in this assay, from the lowest: compounds 1 and 2 (each within the scatter of the next); then compound 4; then compound 3.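

In this assay, the aryl group on the saturated ring carbon of the three-membered ring can now be read on its own, with the amine-bearing chain held fixed: 2,4-difluorophenyl in place of 4-chlorophenyl gives a 3.3-fold lower number from compound 3 to compound 4 (0.52 log units; beyond the scatter). The number at this place therefore responds to the aryl group, though the step is modest and compound 4 still reads 1300 nM. No measurement at hand explains the step, and the data do not tell which feature of the exchange matters.

A single step cannot separate the loss of chlorine from the entry of either fluorine, so 4-fluorophenyl and 2-fluorophenyl on this chain would be the direct tests. Going by these compounds, it also remains open how much of the weak numbers of compound 3 and compound 4 belongs to the chain rather than the aryl group, which an unsubstituted phenyl on this same chain would address.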